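A few compounds are considered here, and "the series" means these few. Any claim that something is new, unique, unknown or untested is made for them only; others in the source may bear on it.

Three compounds have numbers in a functional assay on BGC-823 cells (Homo sapiens) for antiproliferative activity, read by MTT assay; a lower number here means a stronger inhibitor, a higher number a weaker inhibitor:
compound 1 `COc1cc(-c2nnc(Sc3ncnc4ccccc34)o2)cc(OC)c1OC` gives 34500 nM;
compound 2 `C=CCSc1ncnc2ccccc12` gives 78100 nM;
compound 3 `C=CCSc1ncnc2ccc(I)cc12` gives 33200 nM.

Compound 3 has the lowest of the three numbers in this assay. Its nearest neighbour is compound 1, whose value lies within the scatter of that of compound 3, so the two cannot be ordered; the farthest is compound 2. Within the data shown here, the only step between measured compounds that differ in a single place is a 2.4-fold lower number from compound 2 to compound 3 (0.37 log units; beyond the scatter), iodo in place of hydrogen on an aromatic carbon, a modest step beyond the scatter.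

Compound 4 `CCSc1ncnc2ccc(I)cc12` differs from compound 3 at the allylsulfanyl group: methyl in place of vinyl on a saturated chain carbon bound to a sulfur. No measured pair changes this part of the structure; the one step shown concerns the iodo substituent and says nothing about the chain on the sulfur. Among the measured compounds shown here, with no step bearing on it, no change beyond the scatter is expected in this assay, in either direction, and compound 4 is expected to read a 1.0-fold lower number from compound 3 to compound 4 (0.00 log units; within the scatter). For compound 4 the estimate in this assay is 33000 nM, with a range from 12000 nM to 90000 nM, the width reflecting the absence of any step that tests this change.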

Compound 4, half-maximal inhibitory concentration: 31100 nM
Compound 4: the middle estimate sits 1.1-fold (0.03 log units) above what was measured; the range from low to high includes it.
By their numbers in this assay, from the lowest: compounds 4, 3 and 1 (each within the scatter of the next); then compound 2.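

In this assay, among these compounds, the exchange of allylsulfanyl for ethylsulfanyl gives a 1.1-fold lower number from compound 3 to compound 4 (0.03 log units; within the scatter), the first reading at the chain on the sulfur, and compound 3 and compound 4 cannot be told apart. With the iodo substituent in place, then, the double bond of the allyl chain is not required for a reading at this level, and a methyl in place of the vinyl is tolerated on this saturated chain carbon bound to a sulfur. The iodo step, a 2.4-fold lower number from compound 2 to compound 3 (0.37 log units; beyond the scatter), remains the only single-place step beyond the scatter, and nothing shown explains why the chain exchange leaves the reading unresolved.

On these data alone, this rests on one pair carrying the iodo substituent, so it remains open whether allyl and ethyl would also read alike on the core of compound 2. Also open, as far as these compounds go, is whether a longer chain such as butyl, or a chain ending in an amine or a carboxylic acid, would move the number beyond the scatter, and whether bromo or chloro would do what iodo does.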